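Swapping fluoro for chloro on a weak vinyl sulfone

A few compounds are considered here, and "the series" means these few. Any claim that something is new, unique, unknown or untested is made for them only; others in the source may bear on it.

This account follows a series of styryl sulfones tested in an assay on U2OS cells for activation of nuclear factor erythroid 2-related factor 2 (Homo sapiens), read by beta-arrestin recruitment, with a stated time of 6 h; a lower number here means that less compound is needed, a higher number that more compound is needed for the effect. Compound 1 `O=S(=O)(/C=C\c1ncccc1F)c1cccc(Cl)c1` gives 252 nM, and compound 2 `O=S(=O)(/C=C/c1ccc(Cl)cn1)c1cccc(Cl)c1` gives 1510 nM. Compound 3 `O=S(=O)(/C=C/c1ccc(Cl)nc1)c1ccc(F)cc1` reaches only a limit of this assay, > 10000 nM, so its true value is not known. Compound 3 thus stands at the limit of > 10000 nM in this assay, at which 1 of the 3 values shown sits, the weakest point shown. Compound 4 `O=S(=O)(/C=C/c1ccc(Cl)nc1)c1ccc(Cl)cc1` differs from compound 3 by chloro in place of fluoro on an aromatic carbon, placed para to a large group. No directly comparable pair is known, so no step is shown for this change. Compound 4 is expected to stay weak, with an estimate of 8000 nM, between 1500 nM and 30000 nM, meaning an expected step of an at least 1.2-fold lower number from compound 3 to compound 4 (0.09 log units; that floor lies within the scatter).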

Compound 4, half-maximal effective concentration: > 10000 nM
Compound 4 gave a limit, no number; the forecaster's own chance of this, stated with the estimate: 50%; middle value at least 1.2-fold (0.09 log units) away from the limit.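

Among the compounds shown here, compound 3 and compound 4 both end at a limit rather than a number, so no step between them can be read: the limit of > 10000 nM in this assay, at which 2 of the 4 values shown sit. The compounds shown leave open whether chloro in place of fluoro changes the true value at all.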